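Ester to amide at the carbonyl of compound 1: a second case

The compounds below may be only part of what the source reports. "The series", "measured", "known", "first", "only" and "open" are said of these compounds alone.

Measured so far:
compound 1 `C#CC(C)OC(=O)c1ccc(C(CC)(CC)c2ccc(OCCC(O)(CC)CC)c(C)c2)n1CC` > 50000 nM
compound 2 `CCOC(=O)CN(C)C(=O)c1ccc(C(CC)(CC)c2ccc(OCCC(O)(CC)CC)c(C)c2)n1CC` 1990 nM

In an ADME assay on L02 cells (Homo sapiens) for antiproliferative activity, read by MTT assay, with a stated time of 48 h (a lower number here means a stronger inhibitor, a higher number a weaker inhibitor), compound 1 gives only a limit, > 50000 nM; (the limit of > 50000 nM in this assay, at which 1 of the 2 values shown sits). Compound 2 gives 1990 nM in this assay. Among the compounds with values here, the one measured step, an at least 25-fold lower number from compound 1 to compound 2 (1.40 log units; beyond the scatter), is large. Compound 3 `CCn1c(C(=O)NC(C)C(=O)O)ccc1C(CC)(CC)c1ccc(OCCC(O)(CC)CC)c(C)c1` differs from compound 1 in the same place: (1-carboxyethyl)amino in place of (1-methylprop-2-yn-1-yl)oxy on a carbonyl carbon. As in that step, an amide replaces the ester, so a lower number is expected for compound 3, yet the entering group differs from that of compound 2, so the estimate an at least 7.1-fold lower number from compound 1 to compound 3 (0.85 log units; beyond the scatter) is given with a wide range. Compound 3 is expected to give 7000 nM, between 1500 nM and 40000 nM.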

Compound 3, half-maximal inhibitory concentration: 4040 nM
Compound 3: middle estimate off by 1.7-fold (0.24 log units), on the high side, within the range that was stated.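

In this assay, within the data shown here, a second amide on the carbonyl carbon also gives a large step from the ester, an at least 12-fold lower number from compound 1 to compound 3 (1.09 log units; beyond the scatter), so this change is not tied to the one entering group of compound 2. As far as these compounds go, the value of compound 1 is a limit, so the true size of both steps from it stays unknown: the limit of > 50000 nM in this assay, at which 1 of the 3 values shown sits. The two amides are also separated, with a 2.0-fold higher number from compound 2 to compound 3 (0.31 log units; beyond the scatter). From the compounds shown here alone, whether a plain methylamino group on the carbonyl carbon, carrying neither a carboxylic acid nor an ester, would give a similar value remains open.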